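This account rests on a few compounds, and the source may have more. Where it says the series, first, only, none or still open, it means among the compounds named here.

Working notes on the series. In an ADME assay on Huh7.5.1 cells (Homo sapiens) for cytotoxicity, read by ATP content, with a stated time of 48 h (on this read-out lower numbers stand for higher toxicity in this test and higher numbers for lower toxicity in this test), compound 1 (`Cc1ccccc1-c1nc(CN2CCC(C(=O)NCCCN3CCC(C(C)C)CC3)CC2)c(C)o1`) gives 4280 nM and lies within the scatter of compound 3 (`Cc1oc(-c2ccc(Cl)c(Cl)c2)nc1CN1CCC(C(=O)NCCCN2C[C@H](C)C[C@H](C)C2)CC1`) at 3170 nM on the same read-out. Compound 2 (`Cc1oc(-c2ccc(Cl)cc2)nc1CN1CCC(C(=O)NCCCN2C[C@H](C)C[C@H](C)C2)CC1`) at 11500 nM stands higher than compound 1, beyond the scatter.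

Compound 4 (`Cc1ccccc1-c1nc(CN2CCC(C(=O)NCCCN3CCCC(C(C)C)C3)CC2)c(C)o1`) has the same atoms as compound 1, joined differently. The change is a group of 9 heavy atoms (8 carbon, 1 nitrogen; one six-membered non-aromatic ring with 1 hetero atom) in place of a group of 9 heavy atoms (8 carbon, 1 nitrogen; one six-membered non-aromatic ring with 1 hetero atom), on a saturated chain carbon, three bonds along the chain from an amide-type nitrogen and it removes the 4-isopropylpiperidin-1-yl group.

Within the data shown here, the only measured step between two compounds differing in one place is a 3.6-fold lower number from compound 2 to compound 3 (0.56 log units; beyond the scatter) (chloro in place of hydrogen on an aromatic carbon) and it is modest. Among the measured compounds shown here, that change sits on an aromatic carbon and not on a saturated chain carbon, so it shows only that one small change can move this assay beyond the scatter in these compounds. It gives no direction for the present change. For the measured compounds named here, no measured pair covers this exchange of groups.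

No step beyond the scatter is therefore expected, and the working expectation is a 1.1-fold lower number from compound 1 to compound 4 (0.03 log units; within the scatter) with no firm direction. Compound 4 is estimated at 4000 nM with an expected range from 2000 nM to 8000 nM in this test.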

Compound 4, half-maximal cytotoxic concentration: 5820 nM
Beside the measured number, compound 4's estimate is 1.5-fold (0.16 log units) below it, and the stated range covers the measured number.
By their numbers in this assay, from the lowest: compounds 3, 1, 4 and 2 (each within the scatter of the next, the first and the last beyond it).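

In this assay, replacing the 4-isopropylpiperidin-1-yl group with a group of the same atoms joined differently, on a saturated chain carbon, three bonds along the chain from an amide-type nitrogen, gives a 1.4-fold higher number from compound 1 to compound 4 (0.13 log units; within the scatter). Among these compounds, this is the first measured step at this place, and it shows that this exchange, which leaves the counted atoms, ring type, hydrogen-bond donors and acceptors and net charge unchanged, does not separate the two compounds in this test, whereas a 3.6-fold lower number from compound 2 to compound 3 (0.56 log units; beyond the scatter) on an aromatic carbon lies beyond the scatter. Nothing available explains the result at this place, and a single step within the scatter fixes no direction.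

As far as these compounds go, the step covers only one rearrangement of atoms on the core of compound 1, so it remains open whether a morpholine, a piperazine or an open-chain diethylamino group at the same place would also stay within the scatter. From the compounds shown here alone, it also remains open whether the same exchange would stay within the scatter on a core carrying the chlorophenyl or dichlorophenyl group of compound 2 and compound 3.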